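The compounds below may be only part of what the source reports. "The series", "measured", "known", "first", "only" and "open" are said of these compounds alone.

Of the compounds shown here, two have numbers so far. In a functional assay on HCT-116 cells (Homo sapiens) for antiproliferative activity, read by MTT assay, with a stated time of 72 h (a higher number here means a weaker inhibitor, a lower number a stronger inhibitor), compound 1 `COc1ccc(/C=C2/CN(C)/C(=N/c3ccc(OC)cc3)S2)cc1` gives 15900 nM and compound 2 `COc1ccc(/C=C2\S/C(=N\c3ccc(F)cc3)N(C)C2=O)cc1` gives 13300 nM. Among the measured compounds shown here, these two values lie within the scatter of each other, so compound 1 stands level with the only other measured member. Compound 3 `COc1ccc(/C=C2/CN(C)/C(=N/c3ccc([N+](=O)[O-])cc3)S2)cc1` keeps the core of compound 1 and carries nitro in place of methoxy on an aromatic carbon, para to a large group (nitro in place of methoxy on an aromatic carbon). For the measured compounds named here, no measured pair differs in one place only, so the data give no direct size for such a change. With nothing to argue for a large move in either direction, no shift beyond the scatter is expected in this assay. The expected move is a 1.1-fold lower number from compound 1 to compound 3 (0.06 log units; within the scatter), an estimate that stays within the scatter. For compound 3 the estimated value is 14000 nM, with an expected range of 5000 nM to 40000 nM.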

Compound 3, half-maximal inhibitory concentration: 10200 nM
Estimate against measurement, compound 3: 1.4-fold (0.14 log units) above, within the range that was stated.
By their numbers in this assay, from the lowest: compounds 3, 2 and 1 (each within the scatter of the next).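

In this assay, among the compounds shown here, the first single-place comparison reads a 1.6-fold lower number from compound 1 to compound 3 (0.19 log units; within the scatter). At this aromatic carbon, para to a large group, nitro in place of methoxy therefore gives no shift beyond the scatter, although the entering and leaving groups differ in their atoms. No measured information on these compounds bears on this result, and it gives no cause for it.

On these data alone, with only methoxy and nitro compared at this position, it remains open whether an amine, a carboxylic acid or a longer chain would move the number beyond the scatter. Compound 2 differs from compound 1 in more than one place, so the contributions of its fluorine and its carbonyl cannot be read separately.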